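Swapping a Methyl for a Methoxycarbonyl Group

The source may report more compounds than this note shows. Statements on the series, on what has been measured and on what is new or still open speak of the compounds shown alone.

Of the compounds shown here, two have numbers so far. In a functional assay on A549 cells (Homo sapiens) for inhibition (on this read-out higher numbers stand for weaker inhibition and lower numbers for stronger inhibition), compound 1 `O=C1C=CC(OCC(F)(F)F)N1c1cc(Cl)cc(Cl)c1` gives 1630 nM. In this assay compound 2 `Cc1ccc(N2C(=O)C=CC2OCC(F)(F)F)cc1` gives 13700 nM, the higher of the two numbers, and the gap to compound 1 lies beyond the scatter. Compound 3 `COC(=O)c1ccc(N2C(=O)C=CC2OCC(F)(F)F)cc1` differs from compound 2 by methoxycarbonyl in place of methyl on an aromatic carbon. Among the measured compounds shown here, no measured pair shows this change, so its effect is uncertain; a modest step toward a lower number is expected, a 1.7-fold lower number from compound 2 to compound 3 (0.23 log units; within the scatter). Compound 3 is therefore estimated at 8000 nM, with a range from 2000 nM to 30000 nM.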

Compound 3, half-maximal inhibitory concentration: 8170 nM
Compound 3: the middle estimate sits 1.0-fold (0.01 log units) below what was measured; low and high end bracket the measured number.
By their numbers in this assay, from the lowest: compound 1; then compounds 3 and 2 (each within the scatter of the next).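

In this assay, methoxycarbonyl in place of methyl on an aromatic carbon, para to a large group, gives a 1.7-fold lower number from compound 2 to compound 3 (0.22 log units; within the scatter). This position therefore accepts the larger group, with its hydrogen-bond acceptors, while the read-out stays within the scatter of the methyl compound. No measurement at hand gives a reason for this result.

Going by these compounds, whether a carboxylic acid, an amine or a nitrile on this carbon would move the number beyond the scatter remains open. So does whether methoxycarbonyl would give a similar step on another aromatic carbon.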